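Shortening the chain on an aryl-piperazine succinimide amide

The source may hold more compounds than are shown below. What is called first, only, known or untested is meant among the compounds shown, and "the series" means these compounds.

Measured so far:
compound 1 `COc1cccc(N2CCN(C(=O)C(C)N3C(=O)CCC3=O)CC2)c1` — 0%
compound 2 `CC(C(=O)N1CCN(c2ccc(Cl)cc2)CC1)N1C(=O)CCC1=O` — 0%
compound 3 `CCC(C(=O)N1CCN(c2cccc(C)c2)CC1)N1C(=O)CCC1=O` — 75%

In a functional assay on the whole organism (strain Swiss) with Mus musculus as the target, in the maximal electroshock model, with a stated time of 1 h, at a dose of 300 mg/kg by the intraperitoneal route (a higher number here means a stronger effect of the compound at the dose given, a lower number a weaker effect), compound 3 stands highest of the three, beyond the scatter above compound 1 and compound 2, which both show no measurable effect. For the measured compounds named here, the only single-site step measured so far, no change at the digits printed from compound 1 to compound 2 (within the scatter), swaps one aromatic group for another and changes nothing. Compound 4 `Cc1cccc(N2CCN(C(=O)C(C)N3C(=O)CCC3=O)CC2)c1` is made from compound 3 by the change (hydrogen in place of methyl on a saturated chain carbon, two bonds along the chain from an amide-type nitrogen in a ring and a carbonyl carbon). Going by the values given here, no measured step covers this particular change, so it can only be weighed indirectly: compound 1 and compound 2, which both carry the shorter chain of compound 4, gave no effect, while compound 3 with the longer chain gave a clear one, but compound 3 also differs from those two in its aromatic group. The expectation for compound 4 is therefore a loss, estimated as the step of a number 45 percentage points lower from compound 3 to compound 4 (beyond the scatter), with wide uncertainty. Compound 4 is expected to give about 30% in this assay, somewhere between 0% and 75%.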

Compound 4, a percentage reported as activity, at one dose (the size of the read-out at that dose, not a potency): 0%
Estimate against measurement, compound 4: 30 percentage points above, within the range that was stated.
By their numbers in this assay, from the lowest: compounds 1, 2 and 4 (each within the scatter of the next); then compound 3.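

In this assay hydrogen in place of methyl on a saturated chain carbon, two bonds along the chain from an amide-type nitrogen in a ring and a carbonyl carbon, gives a number 75 percentage points lower from compound 3 to compound 4 (beyond the scatter) and leaves the 3-methylphenyl group untouched, so the ethyl to methyl change alone separates a clear effect from none. With the shorter chain in place, the aromatic group does not restore any effect: the result is no change at the digits printed from compound 2 to compound 4 (within the scatter) and also no change at the digits printed from compound 1 to compound 4 (within the scatter) for the aromatic groups compared here. Nothing measured here explains why this small chain change matters so much.

The compounds shown leave open whether a longer chain such as propyl at this carbon would keep the effect. They also leave open whether the ethyl chain gives an effect with 4-chlorophenyl or 3-methoxyphenyl in place of 3-methylphenyl.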